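Compound 3: a new group on the aromatic nitrogen

The compounds below may be only part of what the source reports. "The series", "measured", "known", "first", "only" and "open" are said of these compounds alone.

Going by the values given here, in an ADME assay on J774.A1 cells (Mus musculus) for cytotoxicity, read by MTT assay, with a stated time of 48 h (on this read-out lower numbers stand for higher toxicity in this test and higher numbers for lower toxicity in this test), compound 1 `CCc1ccc(-n2cc(COC(=O)c3c(C)nc4ccc(Cl)cc4c3-c3ccccc3)nn2)cc1` gives 99000 nM and compound 2 `Cc1nc2ccc(Cl)cc2c(-c2ccccc2)c1C(=O)OCc1cn(Cc2ccc([N+](=O)[O-])cc2)nn1` gives 75000 nM, so compound 2 stands within the scatter of the only other measured compound. Compound 3 `Cc1ccc(-n2cc(COC(=O)c3c(C)nc4ccc(Cl)cc4c3-c3ccccc3)nn2)cc1F` keeps the shared core and differs from compound 2 as follows: 3-fluoro-4-methylphenyl in place of 4-nitrobenzyl on an aromatic nitrogen. Among the compounds with values here, one measured step bears on this change, since compound 1 carries 4-ethylphenyl on that same nitrogen. That step, a 1.3-fold lower number from compound 1 to compound 2 (0.12 log units; within the scatter), is small, although a single step is thin evidence. No shift beyond the scatter is therefore expected, and the estimated step is a 1.1-fold higher number from compound 2 to compound 3 (0.06 log units; within the scatter) in this assay, with no firm direction. The estimate for compound 3 is 86000 nM, with 40000 nM to 185000 nM as its expected range.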

Compound 3, half-maximal cytotoxic concentration: 34000 nM
Compound 3: the middle estimate sits 2.5-fold (0.40 log units) above what was measured; measured number below the stated range.
By their numbers in this assay, from the lowest: compound 3; then compounds 2 and 1 (each within the scatter of the next).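

In this assay, the group on this aromatic nitrogen now moves the number beyond the scatter: the change gives a 2.2-fold lower number from compound 2 to compound 3 (0.34 log units; beyond the scatter) and also a 2.9-fold lower number from compound 1 to compound 3 (0.46 log units; beyond the scatter), whereas the earlier swap between 4-ethylphenyl and 4-nitrobenzyl did not. Both steps are modest, but they leave compound 3 with the lowest number of the three, which means the highest toxicity in this test, so this position is not indifferent to the group it carries. Nothing available explains why 3-fluoro-4-methylphenyl behaves this way.

Each step replaces a whole group, so the shift cannot be assigned to the fluorine or to the methyl alone. On these data alone, it also remains open how this position would respond to a simple phenyl, an amine-bearing benzyl, a carboxylic acid or a longer alkyl chain on the same nitrogen.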